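Anilino substituent swap in the styryl series

This account rests on a few compounds, and the source may have more. Where it says the series, first, only, none or still open, it means among the compounds named here.

Compound 1 `CC(=O)Oc1ccccc1/C=C/c1nc2ccccc2c(=O)[nH]1` returns only a limit in a functional assay on MCF7 cells (Homo sapiens) for antiproliferative activity, with a stated time of 72 h (on this read-out lower numbers stand for stronger inhibition and higher numbers for weaker inhibition), > 25000 nM, and not a number. In this assay compound 2 `CC(=O)Oc1ccccc1/C=C/c1nc(Nc2ccccc2I)c2ccccc2n1` gives 15600 nM and compound 3 `COc1ccccc1/C=C/c1nc(Nc2ccccc2Cl)c2ccccc2n1` gives 18900 nM. These two numbers lie within the scatter of each other, so compound 3 stands level with compound 2 in the micromolar range, and the series shows no strong inhibition so far.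

Compound 4 `COc1ccccc1/C=C/c1nc(Nc2cccc(O)c2)c2ccccc2n1` keeps the methoxy-bearing styryl part and the shared core of compound 3, with 3-hydroxyphenyl in place of 2-chlorophenyl on a nitrogen on an aromatic ring. Among the compounds with values here, no measured step between compounds differing in one place is available to size this change, so compound 3 at 18900 nM is the only anchor for the estimate. In this assay the expected result is a small shift towards lower numbers, not clearly beyond the scatter, with the estimated step being a 1.9-fold lower number from compound 3 to compound 4 (0.28 log units; within the scatter). Compound 4 is expected at 10000 nM, with an estimated range from 3000 nM to 25000 nM.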

Compound 4, half-maximal inhibitory concentration: 11200 nM
Compound 4: the middle estimate sits 1.1-fold (0.05 log units) below what was measured; the range from low to high includes it.
By their numbers in this assay, from the lowest: compounds 4, 2 and 3 (each within the scatter of the next). At a limit, above all of these: compound 1.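

In this assay, within the data shown here, the exchange on a nitrogen on an aromatic ring gives the series its only sized step, a 1.7-fold lower number from compound 3 to compound 4 (0.23 log units; within the scatter), and that step stays within the scatter. The hydrogen-bond donor and acceptor that enter with 3-hydroxyphenyl, together with the loss of the chlorine of 2-chlorophenyl, therefore leave the read-out level at this position, still in the micromolar range. The step is read between two numbers and not against the limit of the assay, which only compound 1 reaches: the limit of > 25000 nM in this assay, at which 1 of the 4 values shown sits.

This single exchange alters both the substituent and its place on the ring, so the two cannot be told apart. Going by these compounds, how an unsubstituted phenyl, an aminophenyl or a carboxyphenyl group on this nitrogen would read remains open, as does any change to the methoxy group of the styryl part.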